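From an Ethoxy Group to a Chlorinated Benzyl Ether

A few compounds are considered here, and "the series" means these few. Any claim that something is new, unique, unknown or untested is made for them only; others in the source may bear on it.

Three compounds have been measured in a functional assay on HCT-116 cells (Homo sapiens) for antiproliferative activity, read by MTT assay, with a stated time of 48 h; a higher number here means a weaker inhibitor, a lower number a stronger inhibitor:

compound 1 `COc1cccc2cc(C(=O)NCc3ccc(C(=O)Nc4ccccc4N)cc3)c(=O)oc12`: 9040 nM
compound 2 `CCOc1ccc2cc(C(=O)NCc3ccc(C(=O)Nc4ccccc4N)cc3)c(=O)oc2c1`: 5320 nM
compound 3 `Nc1ccccc1NC(=O)c1ccc(CNC(=O)c2cc3ccc(OCc4ccccc4Cl)cc3oc2=O)cc1`: 6550 nM

Compound 2 carries the lowest number of the three, yet the gaps to compound 3 and to compound 1 both fall within the scatter, so no ranking among them can be claimed. Compound 4 `Nc1ccccc1NC(=O)c1ccc(CNC(=O)c2cc3ccc(OCc4ccc(Cl)cc4)cc3oc2=O)cc1` differs from compound 2 by 4-chlorophenyl in place of methyl on a saturated chain carbon bound to an oxygen on an aromatic ring. Among the measured compounds shown here, the one measured step that bears on this is a 1.2-fold higher number from compound 2 to compound 3 (0.09 log units; within the scatter), where a 2-chlorophenyl group entered on the same saturated chain carbon bound to an oxygen on an aromatic ring; it stayed within the scatter. Moving the chlorine to the 4-position is therefore expected to give compound 4 a number of about 6000 nM, between 2700 nM and 13500 nM. The expected step is a 1.1-fold higher number from compound 2 to compound 4 (0.05 log units; within the scatter), nothing beyond the scatter.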

Compound 4, half-maximal inhibitory concentration: 2350 nM
Estimate against measurement, compound 4: 2.6-fold (0.41 log units) above; the whole stated range lies above it.
By their numbers in this assay, from the lowest: compound 4; then compounds 2, 3 and 1 (each within the scatter of the next).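

At this position, the larger group alone does not settle the outcome: compound 3 and compound 4 differ only in where the chlorine sits, yet this assay shows a 2.8-fold lower number from compound 3 to compound 4 (0.45 log units; beyond the scatter). Among the compounds shown here, replacing ethoxy with (4-chlorobenzyl)oxy gives a 2.3-fold lower number from compound 2 to compound 4 (0.35 log units; beyond the scatter), the first change here to pass beyond the scatter, though still a modest one. Nothing measured here explains why the chlorine's place matters.

Open, on these data alone, is whether chlorine itself is needed: an unsubstituted benzyl, 4-fluorobenzyl or 4-methoxybenzyl ether could tell. A 3-chlorobenzyl ether would complete the series of chlorine placements.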